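The source may hold more compounds than are shown below. What is called first, only, known or untested is meant among the compounds shown, and "the series" means these compounds.

Among the compounds with values here, compound 1 `O=c1c([C@@H]2C[C@H](c3ccccc3)ON2c2ccccc2)coc2ccc(F)cc12` and compound 2 `COC(=O)[C@@]1(C)C[C@@H](c2coc3ccc(F)cc3c2=O)N(c2ccccc2)O1` are the two compounds with numbers so far. In a functional assay on PC-3 cells (Homo sapiens) for inhibition, read by sulforhodamine B assay, with a stated time of 48 h (a lower number here means a stronger inhibitor, a higher number a weaker inhibitor), compound 1 gives 49000 nM, and in this assay compound 2 gives 31300 nM. Within the data shown here, the two numbers lie within the usual scatter of each other, so neither compound stands apart from the other, and nothing further can be said about what separates them, since the two structures differ in more than one place and no single step between them has been worked out.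

The account now follows the step from compound 1 to compound 3 `O=c1c([C@@H]2C[C@H](c3ccccc3)ON2c2ccccc2)coc2ccccc12`. The change is small in what it counts: hydrogen in place of fluoro on an aromatic carbon. Among the measured compounds shown here, on the evidence of the two numbers in hand there is no measured step of this kind, so any expectation rests on the size of the change alone. Compound 3 is expected to sit close to compound 1, with a step of a 1.0-fold higher number from compound 1 to compound 3 (0.01 log units; within the scatter) that stays inside the scatter. For compound 3 in this assay the estimate is 50000 nM, with a range from 20000 nM to 120000 nM.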

Compound 3, half-maximal inhibitory concentration: > 60000 nM
Compound 3 was reported as a limit; the forecaster's own chance of this, stated with the estimate: 20%; middle value at least 1.2-fold (0.07 log units) away from the limit.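

The reading for compound 3 in this assay is a limit of the assay and not a number: the limit of > 60000 nM in this assay, at which 1 of the 3 values shown sits. Set against compound 1, it gives the first step seen at this aromatic carbon, an at least 1.2-fold higher number from compound 1 to compound 3 (0.08 log units; that floor lies within the scatter), so hydrogen in place of fluoro shows no sign of giving a stronger inhibitor in this series. How far the step runs past that floor cannot be read, and the result therefore leaves it undecided whether the fluoro counts for anything here or the pair simply sits within the scatter of each other.

The compounds shown leave open what a different group on this same aromatic carbon would do, such as chloro, methoxy or an amine, as fluoro and hydrogen are the only two seen there. Also open, on these data alone, is whether hydrogen in place of fluoro would give a step that can be read as a number on compound 2, which carries the fluoro as well but differs from compound 1 elsewhere.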